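Swapping the imidazole for a triazole on a dihydropyridine

The source may report more compounds than this note shows. Statements on the series, on what has been measured and on what is new or still open speak of the compounds shown alone.

Compound 1 `CCO/C(O)=C1\C(COCCn2c(C)nc(C)c2C)=NC(C)=C(C(=O)OC)C1c1ccccc1Cl` is the reference point of this small set. In a functional assay (aorta) with Rattus norvegicus as the target (on this read-out higher numbers stand for weaker inhibition and lower numbers for stronger inhibition), compound 1 gives 5.01 nM, the lowest of the three numbers seen so far, which on this read-out means the strongest inhibition. Compound 2 `CCO/C(O)=C1\C(COCCN2CC(=O)N=C2N)=NC(C)=C(C(=O)OC)C1c1ccccc1Cl` gives 20 nM in this assay, and compound 3 `CCO/C(O)=C1\C(COCCn2c(N)cnc2O)=NC(C)=C(C(=O)OC)C1c1ccccc1Cl` gives 158 nM.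

Compound 4 `CCO/C(O)=C1\C(COCCn2ccnn2)=NC(C)=C(C(=O)OC)C1c1ccccc1Cl` has not yet been measured. It differs from compound 1 in one place: 1H-1,2,3-triazol-1-yl in place of 2,4,5-trimethyl-1H-imidazol-1-yl on a saturated chain carbon, two bonds along the chain from an oxygen on a saturated carbon. The ring that leaves carries three methyl groups; the ring that enters carries none and has one more ring nitrogen.

Two measured steps change the same ring on the same chain. The step of a 4.0-fold higher number from compound 1 to compound 2 (0.60 log units; beyond the scatter) and the step of a 32-fold higher number from compound 1 to compound 3 (1.50 log units; beyond the scatter) both replace the trimethylimidazolyl with a smaller, nitrogen-richer ring, and both weakened inhibition, one modestly and one strongly. The triazole of compound 4 is also smaller and nitrogen-richer, so a weaker result than compound 1 is expected, most likely of modest size.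

Compound 4 is therefore expected to give about 25 nM in this assay, within a range of 8 nM to 100 nM, which would mean an estimated step of a 5.0-fold higher number from compound 1 to compound 4 (0.70 log units; beyond the scatter).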

Compound 4, half-maximal inhibitory concentration: 15.9 nM
The estimate for compound 4 lay 1.6-fold (0.20 log units) above the measured number, and the stated range covers the measured number.
By their numbers in this assay, from the lowest: compound 1; then compounds 4 and 2 (each within the scatter of the next); then compound 3.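

The change from trimethylimidazolyl to 1H-1,2,3-triazol-1-yl at this position, on the saturated chain carbon, gives only a modest loss in this assay, with a 3.2-fold higher number from compound 1 to compound 4 (0.50 log units; beyond the scatter), so a ring with no methyl groups at all can still give a low number here. Ring size alone does not set the result: the triazole is the smallest group in the set, yet the larger 5-amino-2-hydroxy-1H-imidazol-1-yl group sits much higher, as the step in the other direction shows with a 9.9-fold lower number from compound 3 to compound 4 (1.00 log units; beyond the scatter), while the triazole and the non-aromatic ring of compound 2 cannot be told apart, with a 1.3-fold lower number from compound 2 to compound 4 (0.10 log units; within the scatter). No measurement here explains why these rings differ in this way.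

The triazole differs from the trimethylimidazolyl both in its methyl groups and in its extra ring nitrogen, so the compounds shown leave open which of the two changes accounts for the step. From the compounds shown here alone, a plain 1H-imidazol-1-yl group with no methyl groups, or a 1,2,3-triazole carrying methyl groups, would separate the two, and a longer chain between the oxygen and the ring remains untested in this set.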